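Fluoro for methyl on the aromatic ring of compound 3

The source may hold more compounds than are shown below. What is called first, only, known or untested is meant among the compounds shown, and "the series" means these compounds.

Compound 3 `C#CCNC(=O)/C(C)=C(\C)c1ccc(C)cc1` gives 150 mg/kg in a toxicity assay on the whole organism (strain Icem-CET (SPF Caw)) for cytotoxicity, with Mus musculus as the target; on this read-out lower numbers stand for an effect already at smaller amounts and higher numbers for an effect only at larger amounts of compound. Among the compounds with values here, compound 2 `C#CCNC(=O)/C(C)=C(\C)c1ccccc1` gives 150 mg/kg, level with compound 3 within the scatter; both stand together at the highest number of the three measured so far. Compound 1 `C/C(C(=O)NC1CC1)=C(/C)c1ccc(F)cc1`, which carries a different amide substituent and a fluoro group, gives 70 mg/kg, the lowest of the three and beyond the scatter from compound 3. The step of no change at the digits printed from compound 2 to compound 3 (within the scatter) shows that adding methyl on an aromatic carbon left the read-out unchanged.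

Compound 4 `C#CCNC(=O)/C(C)=C(\C)c1ccc(F)cc1` differs from compound 3 by fluoro in place of methyl on an aromatic carbon. Within the data shown here, no measured step exchanges methyl for fluoro directly; the only step on the aromatic carbon, no change at the digits printed from compound 2 to compound 3 (within the scatter), was flat. Among the measured compounds shown here, compound 1, the sole measured fluoro compound, shows a lower number, but it also differs in the amide part, so it gives only a weak hint. A small step toward a lower number is therefore expected, a 1.3-fold lower number from compound 3 to compound 4 (0.12 log units; within the scatter), though within the scatter. Compound 4 is estimated at 115 mg/kg, between 60 mg/kg and 220 mg/kg.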

Compound 4, dose for half-maximal effect: 100 mg/kg
Estimate against measurement, compound 4: 1.2-fold (0.06 log units) above, and the stated range covers the measured number.
By their numbers in this assay, from the lowest: compounds 1, 4, 2 and 3 (each within the scatter of the next, the first and the last beyond it).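

In this assay the aromatic carbon para to a large group now has a direct reading for fluoro, both for methyl (a 1.5-fold lower number from compound 3 to compound 4 (0.18 log units; within the scatter)) and for hydrogen (a 1.5-fold lower number from compound 2 to compound 4 (0.18 log units; within the scatter)), so hydrogen, methyl and fluoro at this place all stay within the scatter of one another. With the aromatic fluoro held constant, the amide side can also be read on its own: propargyl in place of cyclopropyl on the amide-type nitrogen (a 1.4-fold higher number from compound 1 to compound 4 (0.15 log units; within the scatter)) stays within the scatter as well. No measured evidence bears on these small steps.

As far as these compounds go, whether an amine, a carboxylic acid or a methoxy group on this aromatic carbon would move the number beyond the scatter stays open. From the compounds shown here alone, it is equally open whether a longer chain on the amide-type nitrogen would do so.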